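The compounds below may be only part of what the source reports. "The series", "measured", "known", "first", "only" and "open" are said of these compounds alone.

Working notes on the series, read in a functional assay on Jurkat cells (Homo sapiens); on this read-out lower numbers stand for stronger inhibition and higher numbers for weaker inhibition. Compound 3 `CC(C)[C@H](NC(=O)COc1cccc2ccccc12)C(=O)N[C@@H](CC(=O)O)C(=O)COc1cc(F)ccc1F` gives > 100000 nM, which is a limit and not a number. Compound 1 `CC(C)[C@H](NC(=O)COc1cccc2ccccc12)C(=O)N[C@@H](CC(=O)O)C(=O)COc1ccccc1C(F)(F)F` gives > 100000 nM, also a limit. Compound 2 `CC(C)[C@H](NC(=O)COc1cccc2ccccc12)C(=O)N[C@@H](CC(=O)O)C(=O)COc1ccc(OC(F)(F)F)cc1` gives a measured number, 29100 nM. Two values therefore sit at the limit of > 100000 nM in this assay, at which 2 of the 3 values shown sit.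

The steps read as an at least 3.4-fold lower number from compound 1 to compound 2 (0.53 log units; beyond the scatter), an at least 3.4-fold higher number from compound 2 to compound 3 (0.53 log units; beyond the scatter) and a step that the two limits leave unreadable from compound 1 to compound 3. Each of them swaps the whole substituted phenyl, and none adds a single fluoro, so they bear on the next change only indirectly.

Compound 4 `CC(C)[C@H](NC(=O)COc1cccc2ccccc12)C(=O)N[C@@H](CC(=O)O)C(=O)COc1cc(F)c(F)cc1F` follows from compound 3 by fluoro in place of hydrogen on an aromatic carbon, para to a large group. Neither direction is favoured, and no step beyond the scatter is expected, since the starting point of compound 3 is only the limit > 100000 nM. The expected step is a number no higher from compound 3 to compound 4 (the limit leaves the size open). Compound 4 is estimated at 100000 nM, with an expected range of 35000 nM to 300000 nM.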

Compound 4, half-maximal inhibitory concentration: 39300 nM
The estimate for compound 4 lay 2.5-fold (0.41 log units) above the measured number, and the stated range covers the measured number.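

In this assay, fluoro in place of hydrogen on this aromatic carbon, para to a large group, gives an at least 2.5-fold lower number from compound 3 to compound 4 (0.40 log units; beyond the scatter), so a single added fluoro here brings the read-out off the limit, which the earlier whole-phenyl swaps could not show. Set against the other phenyl groups, 2,4,5-trifluorophenyl gives a 1.4-fold higher number from compound 2 to compound 4 (0.13 log units; within the scatter) and an at least 2.5-fold lower number from compound 1 to compound 4 (0.40 log units; beyond the scatter), so it cannot be told apart from 4-(trifluoromethoxy)phenyl in this assay. The values of compound 1 and compound 3 are limits and not numbers, so the steps starting from them give only a bound: the limit of > 100000 nM in this assay, at which 2 of the 4 values shown sit.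

Open, from the compounds shown here alone, is whether a methoxy, an amine or a nitrile on the same carbon would read like fluoro. Also open, going by these compounds, is whether fluoro on this carbon does the same without the other two fluoro groups, as in 4-fluorophenyl.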